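A few compounds are considered here, and "the series" means these few. Any claim that something is new, unique, unknown or untested is made for them only; others in the source may bear on it.

Compound 2 `CCOC(=O)CCCCCOc1cccc(CN(C(=O)c2ccccc2)C(C)C)c1` is the anchor of this pair. In an ADME assay on Raji cells (Homo sapiens) for cytotoxicity, read by CellTiter-Glo and resazurin assay, with a stated time of 72 h (on this read-out higher numbers stand for an effect only at larger amounts of compound and lower numbers for an effect already at smaller amounts), compound 2 gives only a limit, > 26000 nM. Compound 1 `CC(C)N(Cc1cccc(OCCCCCC(=O)O)c1)C(=O)c1ccc(-c2cccc(OCc3ccccc3)c2)cc1` likewise gives in this assay only a limit, > 26000 nM. Compound 2 thus sits at the limit of > 26000 nM in this assay, at which 2 of the 2 values shown sit, with no numbered value anywhere in the set to compare against. Compound 3 `CCOC(=O)CCCCCOc1cccc(CN(C(=O)c2ccc(-c3cccc(-c4nnc(C)o4)c3)cc2)C(C)C)c1` carries 3-(5-methyl-1,3,4-oxadiazol-2-yl)phenyl in place of hydrogen on an aromatic carbon. For the measured compounds named here, no measured step exists for this change; the step expected is an at least 1.3-fold lower number from compound 2 to compound 3 (0.11 log units; that floor lies within the scatter), at most a small shift toward effect at smaller amounts. Compound 3 is estimated at 20000 nM, between 8000 nM and 40000 nM, and may well again be reported as a limit.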

Compound 3, half-maximal effective concentration: > 26000 nM
Compound 3: a limit, no number; the forecaster's own chance of this, stated with the estimate: 60%; at least 1.3-fold (0.11 log units) between middle value and limit.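

In this assay compound 2 and compound 3 both give only limits, and no step can be read between them. Whether 3-(5-methyl-1,3,4-oxadiazol-2-yl)phenyl in place of hydrogen changes the read-out at all stays open, as does where any compound shown would give a numbered value.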